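A few compounds are considered here, and "the series" means these few. Any claim that something is new, unique, unknown or untested is made for them only; others in the source may bear on it.

Three members of the series have numbers in a functional assay on KB cells (Homo sapiens) for antiproliferative activity, read by sulforhodamine B assay, with a stated time of 3 days; a higher number here means that more compound is needed for the effect, a lower number that less compound is needed. Compound 1 `CCCC1=C(OCC(C)C)C(CCC)(CCC)C(=O)/C(=C(O)\C=C\c2ccccc2)C1=O` gives 4.8 uM in this assay. Compound 2 `CCCC1=C(OC)C(CCC)(CCC)C(=O)/C(=C(O)\C=C\c2ccc(Br)cc2)C1=O` gives 1.8 uM; compound 3 `COC1=C(CCC(C)C)C(=O)/C(=C(O)/C=C/c2ccccc2)C(=O)C1(CCC(C)C)CCC(C)C` gives 17.5 uM. Compound 1 therefore stands second highest of the three, with compound 2 at a lower number beyond the scatter and compound 3 at a higher number beyond the scatter. No two of these compounds differ in only one place, so no single change can be read off the measured set.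

The next compound, compound 4 `CCCCOC1=C(CCC)C(=O)/C(=C(O)/C=C/c2ccccc2)C(=O)C1(CCC)CCC`, has not yet been measured in this assay. It differs from compound 1 in one place: propyl in place of isopropyl on a saturated chain carbon bound to an oxygen on an unsaturated carbon. Read one bond further out, the change is isobutoxy to butoxy. Nothing else in the shared core moves.

For the measured compounds named here, no measured pair tells how much such a chain change shifts the number. With the same atoms joined differently and no change in donors, acceptors or charge, the expected step from compound 1 to compound 4 is estimated at a 1.0-fold higher number from compound 1 to compound 4 (0.02 log units; within the scatter), i.e. no change beyond the scatter in either direction. Compound 4 is accordingly expected to give about 5 uM in this assay, within a range of 2 uM to 12 uM.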

Compound 4, concentration for half-maximal effect: 8 uM
The estimate for compound 4 lay 1.6-fold (0.20 log units) below the measured number; low and high end bracket the measured number.
By their numbers in this assay, from the lowest: compound 2; then compounds 1 and 4 (each within the scatter of the next); then compound 3.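

In this assay, for the compounds shown here, the step of a 1.7-fold higher number from compound 1 to compound 4 (0.22 log units; within the scatter) is the first single-place comparison. It shows that propyl in place of isopropyl on a saturated chain carbon bound to an oxygen on an unsaturated carbon, read one bond further out as isobutoxy to butoxy, stays within the scatter, so these two chains cannot be told apart at this position on this one pair. No available evidence bears on the reason for this result.

Still open, on these data alone, is whether a longer chain such as hexyloxy, or a chain ending in an amine or a carboxylic acid, would move the number beyond the scatter at this position. Also open, as far as these compounds go, is whether isobutoxy to butoxy reads the same on a core carrying the bromine of compound 2.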